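The compounds below may be only part of what the source reports. "The series", "measured", "known", "first", "only" and "open" are said of these compounds alone.

Measured so far:
compound 1 `C=CC(C)(C)c1[nH]c2ccc(C[C@@H](Cl)C(C)(C)O)cc2c1/C=C1\NC(=O)[C@H](C)NC1=O` with 97000 nM in a functional assay; a higher number here means a weaker inhibitor, a lower number a stronger inhibitor;
compound 2 `C=CC(C)(C)c1[nH]c2ccc(CC=C(C)C)cc2c1/C=C1\NC(=O)[C@H](C)NC1=O` with 98000 nM in this assay.

Compound 2 gives the highest of the two numbers, and its nearest neighbour is compound 1, separated by a 1.0-fold higher number from compound 1 to compound 2 (0.00 log units; within the scatter), which lies within the scatter. Compound 3 `C=CC(C)(C)c1[nH]c2ccccc2c1/C=C1\NC(=O)[C@H](C)NC1=O` has not been measured. It differs from compound 2 by hydrogen in place of 3-methylbut-2-en-1-yl on an aromatic carbon. Among the measured compounds shown here, no measured step removes this chain altogether; the only step known, from compound 1 to compound 2, reshaped the chain at a saturated chain carbon without any movement beyond the scatter. The change is therefore expected to bring no step beyond the scatter, a 1.1-fold higher number from compound 2 to compound 3 (0.05 log units; within the scatter). Compound 3 is estimated at 110000 nM, ranging from 40000 nM to 300000 nM.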

Compound 3, half-maximal inhibitory concentration: 103000 nM
Compound 3: middle estimate off by 1.1-fold (0.03 log units), on the high side; measured number inside the range.
By their numbers in this assay, from the lowest: compounds 1, 2 and 3 (each within the scatter of the next).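

Taking the chain away entirely, hydrogen in place of 3-methylbut-2-en-1-yl gives a 1.1-fold higher number from compound 2 to compound 3 (0.02 log units; within the scatter) and hydrogen in place of 2-chloro-3-hydroxy-3-methylbutyl gives a 1.1-fold higher number from compound 1 to compound 3 (0.03 log units; within the scatter) in this assay on this aromatic carbon, where earlier only a reshaped chain had been seen. The whole chain, not just its shape, can therefore go from this position with no movement beyond the scatter. No supporting evidence is at hand to explain this. On these data alone, whether an amine or a carboxylic acid on this carbon would give a step beyond the scatter stays open. So does the effect of any change elsewhere on the shared core.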